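The source may report more compounds than this note shows. Statements on the series, on what has been measured and on what is new or still open speak of the compounds shown alone.

In a functional assay on DU-145 cells (Homo sapiens) for inhibition, read by sulforhodamine B assay, with a stated time of 48 h (on this read-out lower numbers stand for stronger inhibition of growth and higher numbers for weaker inhibition of growth), compound 1 (`CCCCCCCCCCCC[C@@H](O)[C@H]1CC[C@H]([C@H](O)CCCCCCCCCCNC(=O)c2ccnn2C)O1`) gives 100000 nM, and compound 2 (`CCCCCCCCCCCC[C@@H](O)[C@H]1CC[C@H]([C@H](O)CCCCCCCCCCC(=O)Nc2ccnn2C)O1`) stands level with it at 100000 nM. Compound 3 (`CCCCCCCCCCCC[C@@H](O)[C@H]1CC[C@H]([C@H](O)CCCCCCCCCCOC(=O)c2ccnn2C)O1`), not yet measured, carries ((1-methyl-1H-pyrazol-5-yl)carbonyl)oxy in place of (1-methyl-1H-pyrazol-5-yl)carbamoyl on a saturated chain carbon, ten or more bonds along the chain from an oxygen on a saturated carbon and a saturated ring carbon. Within the data shown here, the only measured step bearing on this change, no change at the digits printed from compound 1 to compound 2 (within the scatter), lies within the scatter, so no step beyond the scatter is expected in this assay. The expected step is no change at the digits printed from compound 2 to compound 3 (within the scatter). Compound 3 is estimated at 100000 nM, with an expected range of 40000 nM to 150000 nM.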

Compound 3, concentration for 50% growth inhibition: 100000 nM
The estimate for compound 3 equals the measured number at the digits printed, within the range that was stated.
By their numbers in this assay, from the lowest: compounds 1, 2 and 3 (each within the scatter of the next).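

In this assay the ((1-methyl-1H-pyrazol-5-yl)carbonyl)oxy group on this saturated chain carbon gives no change at the digits printed from compound 2 to compound 3 (within the scatter) against the (1-methyl-1H-pyrazol-5-yl)carbamoyl group and no change at the digits printed from compound 1 to compound 3 (within the scatter) against the ((1-methyl-1H-pyrazol-5-yl)carbonyl)amino group. A third linkage, with 0 hydrogen-bond donors where the carbamoyl group has 1, thus stands level with both amide linkages at this position. No measured evidence accounts for this reading. The compounds shown leave open whether an amine, a carboxylic acid or a longer chain at this place would shift the value in this assay at all.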